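From Pyridinyl to Pyridinylmethyl on the Ring Amine

The source may report more compounds than this note shows. Statements on the series, on what has been measured and on what is new or still open speak of the compounds shown alone.

compound 1 `Nc1ccccc1NC(=O)c1ccc(CSC(=S)N2CCc3ccccc32)cc1`: 25.7%
compound 2 `Nc1ccccc1NC(=O)c1ccc(CSC(=S)N2CCN(c3cccnc3)CC2)cc1`: 40.5%

In a functional assay on A-375 cells (Homo sapiens) for antiproliferative activity, read by CCK-8 assay, with a stated time of 72 h, tested at 2 uM (a higher number here means a stronger effect of the compound at the concentration tested, a lower number a weaker effect), compound 2 gives 40.5%, the higher of the two numbers, and compound 1 sits beyond the usual scatter below it. Compound 3 `Nc1ccccc1NC(=O)c1ccc(CSC(=S)N2CCN(Cc3cccnc3)CC2)cc1` differs from compound 2 by (pyridin-3-yl)methyl in place of pyridin-3-yl on an amine nitrogen in a ring. Among the compounds with values here, no measured pair in this set shows what such a change does in this assay. Compound 3 is therefore expected to change only modestly, with a step of a number 5.5 percentage points lower from compound 2 to compound 3 (within the scatter) that may fall within the scatter or slightly downward. Compound 3 is estimated at 35%, with a range from 20% to 50%.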

Compound 3, a percentage reported as inhibition, at one concentration (the size of the read-out at that concentration, not a potency): 31.5%
Estimate against measurement, compound 3: 3.5 percentage points above, and the stated range covers the measured number.
By their numbers in this assay, from the lowest: compounds 1, 3 and 2 (each within the scatter of the next, the first and the last beyond it).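

In this assay, within the data shown here, the step of a number 9 percentage points lower from compound 2 to compound 3 (within the scatter) gives the first reading of this position: (pyridin-3-yl)methyl in place of pyridin-3-yl on the amine nitrogen in the ring stays within the usual scatter. For this one pair, the read-out therefore does not separate the two groups. Nothing measured here offers an explanation for the result.

Going by these compounds, it remains open whether a longer chain, such as (pyridin-3-yl)ethyl, or a phenyl or benzyl group on the same nitrogen would read differently. On these data alone, whether the pair stays this close at other concentrations also remains open.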